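Cyclopropyloxy for ethyl on an imidazoline aryl ether

The compounds below may be only part of what the source reports. "The series", "measured", "known", "first", "only" and "open" are said of these compounds alone.

Going by the values given here, compound 2, `CCc1ccccc1OC(C)C1=NCCN1`, is one of two compounds measured in an assay on CHO cells with Alpha-2C adrenergic receptor (Homo sapiens) as the target; a higher number here means a larger maximal response, a lower number a smaller maximal response. Compound 1, `CC(Oc1ccccc1Br)C1=NCCN1`, gives 0.87 in this assay, while compound 2 gives 0.6, the lowest of the two numbers, with compound 1 the nearest neighbour, its value higher by the measured step. Among the compounds with values here, the only step measured so far, a number 0.27 lower from compound 1 to compound 2 (beyond the scatter), is a modest lowering from the bromo compound to the ethyl compound.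

Compound 3, `CC(Oc1ccccc1OC1CC1)C1=NCCN1`, differs from compound 2 in one place: cyclopropyloxy in place of ethyl on an aromatic carbon. Within the data shown here, the single measured step exchanges a halogen for an alkyl group and so bears only loosely on an exchange of an alkyl group for an oxygen-linked ring; no measured compound carries an oxygen-linked substituent at this position. He therefore expects a step no larger than modest, in either direction, with a change within the scatter the most likely outcome, so that a number 0.050 higher from compound 2 to compound 3 (within the scatter) is his estimate of the step. For compound 3 in this assay he estimates 0.65, within a range from 0.4 to 0.9.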

Compound 3, intrinsic activity: the largest response reached, as a fraction of the reference agonist's: 0.7
Estimate against measurement, compound 3: 0.050 below, within the range that was stated.
By their numbers in this assay, from the lowest: compounds 2 and 3 (each within the scatter of the next); then compound 1.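

In this assay, the exchange at this position gives a number 0.10 higher from compound 2 to compound 3 (within the scatter), so the aromatic carbon ortho to a group of 8 heavy atoms can carry an oxygen-linked substituent as well as an alkyl group without a change beyond the scatter. The entering cyclopropyloxy group brings 4 heavy atoms against the 2 of ethyl, along with a three-membered ring and a hydrogen-bond acceptor, yet the values of compound 2 and compound 3 remain within the scatter of each other. The comparison with the bromo compound gives a number 0.17 lower from compound 1 to compound 3 (beyond the scatter), which leaves compound 1 set apart, beyond the scatter, from both of the other compounds. Nothing available offers an explanation for these numbers.

The three compounds leave open whether the oxygen or the three-membered ring matters more at this position, a question that a methoxy group and a cyclopropyl group would each address from one side. They also leave open how an amine or a carboxylic acid would fare on this aromatic carbon, and whether chlorine or iodine would give a value closer to that of compound 1.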